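One Carbon More Toward the Piperidin-2-yl Group

The compounds below may be only part of what the source reports. "The series", "measured", "known", "first", "only" and "open" are said of these compounds alone.

compound 1 `Clc1ccc(OCc2nc3ccccc3n2CCC2CCCCN2)cc1`: 7860 nM
compound 2 `Clc1ccc(OCc2nc3ccccc3n2CCN2CCCCC2)cc1`: a limit, > 100000 nM
compound 3 `Clc1ccc(OCc2nc3c(OCCCC4CCNCC4)cccc3n2CCCC2CCCNC2)cc1`: 152 nM

In an assay on isolated protein for binding affinity to Neuropeptide Y receptor type 1 (Homo sapiens) (on this read-out higher numbers stand for weaker inhibition and lower numbers for stronger inhibition), compound 1 gives 7860 nM, the highest of the two numbers shown. Compound 3 gives a lower number, 152 nM. For compound 2 the assay reports only a limit, > 100000 nM. Within the data shown here, the one measured step, an at least 12-fold higher number from compound 1 to compound 2 (1.10 log units; beyond the scatter), concerns the point of attachment rather than the chain, and so bears only loosely on the present change. Compound 4 `Clc1ccc(OCc2nc3ccccc3n2CCCC2CCCCN2)cc1` differs from compound 1 by (piperidin-2-yl)methyl in place of piperidin-2-yl on a saturated chain carbon, two bonds along the chain from an aromatic nitrogen. A modest step downward is expected, a 2.6-fold lower number from compound 1 to compound 4 (0.42 log units; beyond the scatter), since compound 3 gives 152 nM with a longer chain yet also carries a further group, which keeps the expectation small. Compound 4 is therefore estimated at 3000 nM, within 600 nM to 15000 nM.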

Compound 4, inhibition constant: 3230 nM
Compound 4: the middle estimate sits 1.1-fold (0.03 log units) below what was measured; the measured number falls inside the stated range.
By their numbers in this assay, from the lowest: compound 3; then compound 4; then compound 1. At a limit, above all of these: compound 2.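

Lengthening the chain by one carbon while keeping the piperidin-2-yl attachment gives a 2.4-fold lower number from compound 1 to compound 4 (0.39 log units; beyond the scatter), so the added carbon alone brings only a modest gain at this place. The step of an at least 30-fold lower number from compound 2 to compound 4 (1.49 log units; beyond the scatter) is much larger, but it changes the ring attachment as well as the chain length, and it is only a bound. Compound 2 gives a limit of the assay rather than a number: the limit of > 100000 nM in this assay, at which 1 of the 4 values shown sits.

From the compounds shown here alone, whether a longer 2-(piperidin-2-yl)ethyl group would lower the number further remains open. So does the separate contribution of a piperidin-3-yl ring on this chain.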